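The source may report more compounds than this note shows. Statements on the series, on what has been measured and on what is new or still open speak of the compounds shown alone.

Measured in a functional assay on MT4 cells (Homo sapiens) for cytotoxicity; a lower number here means a stronger inhibitor, a higher number a weaker inhibitor:
- compound 1 `N#Cc1c(N)cccc1Sc1ccccc1`: 168000 nM
- compound 2 `COc1cccc(Sc2cccc(N)c2C#N)c1`: > 200000 nM (a limit)
- compound 3 `Cc1ccc(Sc2cccc(N)c2C#N)cc1`: > 200000 nM (a limit)

Among the compounds with values here, compound 1 at 168000 nM holds the only actual number in this set. The other two values are limits of the assay, and they share one ceiling: the limit of > 200000 nM in this assay, at which 2 of the 3 values shown sit.

Compound 4 `N#Cc1c(N)cccc1Sc1ccccc1Cl` differs from compound 1 by chloro in place of hydrogen on an aromatic carbon.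

Within the data shown here, two measured steps bear on this change, and each is only a floor. Methoxy in place of hydrogen on an aromatic carbon gives an at least 1.1-fold higher number from compound 1 to compound 2 (0.07 log units; that floor lies within the scatter). Methyl in place of hydrogen on an aromatic carbon gives an at least 1.1-fold higher number from compound 1 to compound 3 (0.07 log units; that floor lies within the scatter). Neither step has a true size, and chloro is a different group from both, so they carry over only loosely. With only these floors to go on, no shift beyond the scatter is expected in this assay, in either direction. Compound 4 may also return only a limit.

The expected change is a 1.1-fold lower number from compound 1 to compound 4 (0.02 log units; within the scatter). For compound 4 the estimated value is 160000 nM. The expected range for compound 4 runs from 70000 nM to 320000 nM.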

Compound 4, half-maximal inhibitory concentration: 33000 nM
Estimate against measurement, compound 4: 4.8-fold (0.69 log units) above; measured number outside the range, below it.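

In this assay, within the data shown here, chloro in place of hydrogen on an aromatic carbon, ortho to a large group, gives the first step in this set that has a true size and lies beyond the scatter (a 5.1-fold lower number from compound 1 to compound 4 (0.71 log units; beyond the scatter)). Its direction is also new: the number moves toward stronger inhibition, whereas the two earlier steps are floors on the higher side. One added chlorine atom therefore moves the core of compound 1 away from the shared ceiling, while the methoxy and methyl steps still cannot be read for size: the limit of > 200000 nM in this assay, at which 2 of the 4 values shown sit.

The compounds shown leave open whether this step belongs to chloro itself or to its place, as a single chloro compound does not separate the two. Fluoro, bromo or an amine at the same place, together with chloro elsewhere on the same ring, would be needed to tell whether the lower number follows the group or the position.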